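The compounds below may be only part of what the source reports. "The series", "measured", "known", "first", "only" and "open" are said of these compounds alone.

Measured in a functional assay on HepG2 cells (Homo sapiens) for antiproliferative activity, read by XTT assay, with a stated time of 72 h; a higher number here means a weaker inhibitor, a lower number a stronger inhibitor:
- Compound 1 `CSc1ncnc2c1c(-c1ccccc1)cn2[C@@H]1O[C@H](CO)[C@@H](O)[C@H]1O`: > 20000 nM (a limit)
- Compound 2 `CNc1ncnc2c1c(-c1ccco1)cn2[C@@H]1O[C@H](CO)[C@@H](O)[C@H]1O`: 850 nM
- Compound 3 `CNc1ncnc2c1c(-c1ccoc1)cn2[C@@H]1O[C@H](CO)[C@@H](O)[C@H]1O`: > 20000 nM (a limit)

Compound 3 yields no number, only (the limit of > 20000 nM in this assay, at which 2 of the 3 values shown sit). Moving to compound 4 `CNc1ncnc2c1c(-c1ccccc1)cn2[C@@H]1O[C@H](CO)[C@@H](O)[C@H]1O` brings (phenyl in place of furan-3-yl on an aromatic carbon), phenyl in place of furan-3-yl on an aromatic carbon. For the measured compounds named here, the one measured step at this place is an at least 23-fold higher number from compound 2 to compound 3 (1.37 log units; beyond the scatter), a large change, so the group here can matter. Compound 1, which also carries phenyl, gives only a limit, > 20000 nM. It differs from compound 4 elsewhere, so it is indirect support. No step beyond the scatter is therefore expected in this assay, in either direction. The expected change is a number no higher from compound 3 to compound 4 (the limit leaves the size open). For compound 4 the estimated value is 20000 nM, with an expected range of 6000 nM to 40000 nM.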

Compound 4, half-maximal inhibitory concentration: > 20000 nM
Compound 4 gave a limit, no number; the forecaster's own chance of this, stated with the estimate: 70%; the middle value lies on the limit itself.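

In this assay compound 4 gives > 20000 nM, which is a limit and not a number. Phenyl in place of furan-2-yl is also a large change, an at least 23-fold higher number from compound 2 to compound 4 (1.37 log units; beyond the scatter), so of the three groups shown at this aromatic carbon with methylamino present, only furan-2-yl gives a measured value. The steps to compound 4 from compound 3 and from compound 1 cannot be read, and limits now dominate the series: the limit of > 20000 nM in this assay, at which 3 of the 4 values shown sit.

Going by these compounds, it remains open how a thiophene ring or a pyridine ring would read at this place. Also open, on these data alone, is whether methylsulfanyl in place of methylamino would change the value of compound 2.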